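A few compounds are considered here, and "the series" means these few. Any claim that something is new, unique, unknown or untested is made for them only; others in the source may bear on it.

Compound 1, `O=C(/C=C/CCCCCCc1ccccc1)Nc1ccccc1`: > 100000 nM in a functional assay on PANC-1 cells (Homo sapiens) for cytotoxicity, read by WST assay, with a stated time of 24 h (on this read-out higher numbers stand for weaker inhibition and lower numbers for stronger inhibition), which is a limit of the assay and not a number.
Compound 2, `O=C(/C=C\CCCCCCc1ccccc1)N1CCCCC1`: > 100000 nM in this assay, again a limit of the assay.
Compound 3, `O=C(CCCCCCCCc1ccc(C(F)(F)F)cc1)N1CCCCC1`: 54000 nM in this assay.

Among the three measured compounds, compound 3 is the only one for which this assay reports a number at all; compound 1 and compound 2 both sit at the limit of > 100000 nM in this assay, at which 2 of the 3 values shown sit. For the measured compounds named here, there is therefore no step between two measured compounds from which the size of a structural change can be read, and compound 3 stands alone as the one fixed point on the scale.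

Compound 4, `O=C(CCCCCCCCc1ccc(Cl)cc1)N1CCCCC1`, differs from compound 3 in one place: chloro in place of trifluoromethyl on an aromatic carbon. Both groups are uncharged and bring neither hydrogen-bond donors nor acceptors, and the position on the aromatic ring is kept. Going by the values given here, with no measured step to lean on, the expectation rests on the modest size of this exchange: compound 4 is expected to come out close to compound 3, with a step of a 1.3-fold higher number from compound 3 to compound 4 (0.11 log units; within the scatter) that lies within the usual scatter, if anything leaning toward weaker inhibition. Compound 4 is thus estimated at 70000 nM in this assay, in a range from 30000 nM to 160000 nM.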

Compound 4, half-maximal inhibitory concentration: 65500 nM
Compound 4: the middle estimate sits 1.1-fold (0.03 log units) above what was measured; the range from low to high includes it.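

For the compounds shown here, the step from trifluoromethyl to chloro on an aromatic carbon, para to a large group, is the first that can be read: a 1.2-fold higher number from compound 3 to compound 4 (0.08 log units; within the scatter). Although 4 heavy atoms give way to 1, the two compounds cannot be told apart in this assay, so for this pair the exchange leaves the read-out unchanged within the scatter. Compound 4 also joins compound 3 as a second compound with a number rather than a limit, while the remaining compounds stay at that limit: the limit of > 100000 nM in this assay, at which 2 of the 4 values shown sit.

What the compounds shown leave open is whether a different group at this place, such as an amine, a methoxy group or a carboxylic acid, would move the number beyond the scatter, and whether the same holds with a shorter chain or with a hydrogen on that aromatic carbon. Compound 1 and compound 2 each differ from compound 3 and compound 4 in more than one place, so their limits say nothing about this position or about this exchange.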